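Swapping the nitrile side chain of compound 3 for an amide

The source may report more compounds than this note shows. Statements on the series, on what has been measured and on what is new or still open speak of the compounds shown alone.

Values in a functional assay on PC-3 cells (Homo sapiens) for cytotoxicity, read by colorimetric assay and MTT assay; on this read-out higher numbers stand for weaker inhibition and lower numbers for stronger inhibition:
- compound 1 `COc1cccc2cc(-c3ccccc3)c(O)nc12`: 10000 nM
- compound 2 `COc1cc(OC)c2cc(-c3ccc(OCc4ccccc4)cc3)c(O)nc2c1`: 10000 nM
- compound 3 `COc1ccc(-c2cc3c(OC)cc(OC)cc3n(CCCC#N)c2=O)cc1`: 10000 nM

In this assay compound 3 reads 10000 nM, level with compound 1 and compound 2, so all three sit together within the scatter and none separates from the others.

The next compound is compound 4 `CCN(CC)C(=O)CCn1c(=O)c(-c2ccc(OC)cc2)cc2c(OC)cc(OC)cc21`. The change is diethylcarbamoyl in place of cyanomethyl on a saturated chain carbon, two bonds along the chain from an aromatic nitrogen.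

For the measured compounds named here, no measured pair differs in one place only, so the data give no direct size for this change. The three compounds share one reading despite their different structures, so no step beyond the scatter is expected in this assay, and no direction is favoured with confidence. The expected change is a 1.1-fold lower number from compound 3 to compound 4 (0.05 log units; within the scatter). For compound 4 the estimated value is 9000 nM, with an expected range of 3500 nM to 12000 nM.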

Compound 4, half-maximal inhibitory concentration: 10000 nM
For compound 4 the middle estimate is 1.1-fold (0.05 log units) below the measured one; measured number inside the range.
By their numbers in this assay, from the lowest: compounds 1, 2, 3 and 4 (each within the scatter of the next).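

In this assay, for the compounds shown here, the first one-place comparison reads no change at the digits printed from compound 3 to compound 4 (within the scatter) for diethylcarbamoyl in place of cyanomethyl on a saturated chain carbon, two bonds along the chain from an aromatic nitrogen. Going by these compounds alone, at this position, the nitrile-bearing side chain and the larger amide-bearing side chain therefore cannot be told apart on this read-out, which the earlier compounds, differing in more than one place, could not show. No supporting data bear on why the reading holds across this change.

As far as these compounds go, whether a primary amine or a carboxylic acid at the end of this side chain would separate from the shared reading remains open. A longer chain carrying the same diethylcarbamoyl group is also an open case at this position.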